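Chain shortening on the hydroxylated core of compound 2

The source may report more compounds than this note shows. Statements on the series, on what has been measured and on what is new or still open speak of the compounds shown alone.

Measured compounds:
- compound 1, `CCCC/C=C\CCCCCCCCC[C@H](O)Cc1cc(O)ccc1O`, 1020 nM
- compound 2, `CCCC/C=C\CCCCCCCCCCC[C@H](O)C[C@]1(O)CC(=O)C=C[C@H]1O`, 390 nM

Of the compounds shown here, two have been measured in a functional assay on Hep293TT cells (Homo sapiens) for inhibition, read by sulforhodamine B assay, with a stated time of 48 h; on this read-out higher numbers stand for weaker inhibition of growth and lower numbers for stronger inhibition of growth. Compound 1 gives 1020 nM, while compound 2 gives 390 nM, the lower of the two numbers. Compound 2 therefore stands as the stronger of the pair, and its gap to compound 1 lies beyond the usual scatter; the two compounds differ in both the core and the chain, so the numbers alone do not say which part carries the gap.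

Compound 3, `CCCC/C=C\CCCCCCCCC[C@H](O)C[C@]1(O)CC(=O)C=C[C@H]1O`, keeps the core of compound 2 and changes only the chain: hex-1-en-1-yl in place of oct-3-en-1-yl on a saturated chain carbon, ten or more bonds along the chain from an oxygen on a saturated carbon. Eight heavy atoms leave and six enter, the single double bond outside aromatic rings is kept, and no donor or acceptor is touched. Going by the values given here, with no measured pair showing the effect of this change on its own, the step from compound 2 to compound 3 is expected to be small, a modest move toward weaker inhibition at most, and possibly none beyond the scatter, as a 1.3-fold higher number from compound 2 to compound 3 (0.12 log units; within the scatter). Compound 3 is thus estimated at 520 nM, in the range 200 nM to 1300 nM.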

Compound 3, concentration for 50% growth inhibition: 500 nM
Compound 3: middle estimate off by 1.0-fold (0.02 log units), on the high side; measured number inside the range.
By their numbers in this assay, from the lowest: compounds 2 and 3 (each within the scatter of the next); then compound 1.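

In this assay, replacing oct-3-en-1-yl with hex-1-en-1-yl on the saturated chain carbon gives (the step reads a 1.3-fold higher number from compound 2 to compound 3 (0.11 log units; within the scatter)), so the chain of compound 2 can take this change at this place without a shift that stands clear of the scatter. Compound 1 and compound 3 carry the same chain and differ only in the core, and that exchange gives a 2.0-fold lower number from compound 1 to compound 3 (0.31 log units; beyond the scatter), a modest step but one that the earlier pair, differing in two places, could not isolate. Of the two differences between compound 1 and compound 2, the core exchange therefore gives a step beyond the scatter, while the chain change stays within it. Nothing shown explains why the numbers fall this way.

The compounds shown leave open how far the chain tolerates change in either direction, for example with a longer chain, a saturated decyl chain or a chain ending in a carboxylic acid. They also leave open whether the core step keeps its size with oct-3-en-1-yl in place of hex-1-en-1-yl, and whether an amine in place of a core hydroxyl would alter the number in this assay at all.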